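Swapping a tert-butoxycarbonyl cap for a cyclopropylcarbonyl one

The compounds below may be only part of what the source reports. "The series", "measured", "known", "first", "only" and "open" are said of these compounds alone.

Compound 1 `CCN(CC)S(=O)(=O)c1ccc(S(=O)(=O)N2CCC[C@@H](C(=O)NC3CN(C(=O)OC(C)(C)C)C3)C2)cc1` carries an azetidine amide whose nitrogen is capped by a tert-butoxycarbonyl group. In a functional assay on MIA PaCa-2 cells (Homo sapiens) for inhibition, read by MTT assay, with a stated time of 7 days (on this read-out lower numbers stand for stronger inhibition and higher numbers for weaker inhibition), compound 1 gives 200 nM, which puts it second highest among the three numbers measured. Its nearest neighbour, compound 2 `CC(C)c1noc(N2CCN(C(=O)[C@@H]3CCCN(S(=O)(=O)c4ccc(S(=O)(=O)C(C)C)cc4)C3)CC2)n1`, gives 70 nM in this assay, a gap that lies beyond the usual scatter. The furthest, compound 3 `CCOC(=O)[C@@H]1CCC[C@H](S(=O)(=O)c2ccc(S(=O)(=O)N(CC)CC)cc2)C1`, which lacks the amide side chain altogether, gives 21500 nM in this assay, far weaker than compound 1.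

Compound 4 `CCN(CC)S(=O)(=O)c1ccc(S(=O)(=O)N2CCC[C@@H](C(=O)NC3CN(C(=O)C4CC4)C3)C2)cc1` keeps everything in compound 1 except the cap on the azetidine nitrogen: cyclopropyl in place of tert-butoxy on a carbonyl carbon. Among the measured compounds shown here, no measured pair in this set shows the effect of such a change, so there is no direct guide. Because the rest of the molecule is unchanged and compound 1 already stands at 200 nM, the step of no change at the digits printed from compound 1 to compound 4 (within the scatter) is expected to be small, within the scatter, with no clear direction. Compound 4 is therefore estimated to give 200 nM in this assay, with a likely range from 70 nM to 600 nM.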

Compound 4, half-maximal inhibitory concentration: 2800 nM
Compound 4: middle estimate off by 14-fold (1.15 log units), on the low side; the measured number lies above the stated range.
By their numbers in this assay, from the lowest: compound 2; then compound 1; then compound 4; then compound 3.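

The cap on the azetidine nitrogen is not a silent position: cyclopropyl in place of tert-butoxy on a carbonyl carbon gives a 14-fold higher number from compound 1 to compound 4 (1.15 log units; beyond the scatter) in this assay and so weakens inhibition. Compounds 1 and 4 differ in this one place, so the step belongs to this change alone, and it shows that activity here depends strongly on what sits on that carbonyl. Nothing measured here explains why this change weakens inhibition.

The change removes an oxygen and alters the carbon group in one move, so the compounds shown cannot separate these two parts. A methoxy cap would keep the oxygen with a smaller carbon group, while a tert-butyl group on the carbonyl would keep the branched carbons without the oxygen.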